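Cyclopentylmethyl on the Ring Nitrogen of Compound 3

The source may report more compounds than this note shows. Statements on the series, on what has been measured and on what is new or still open speak of the compounds shown alone.

Compound 1 `CCCn1c(=O)c(S(=O)(=O)c2ccc(F)cc2F)cc2cnc(Nc3ccc4[nH]ccc4c3)nc21`: 1000 nM
Compound 2 `O=c1c(S(=O)(=O)c2ccc(F)cc2F)cc2cnc(Nc3ccc4[nH]ccc4c3)nc2n1CC1CC1`: 1000 nM
Compound 3 `O=c1[nH]c2nc(Nc3ccc4[nH]ccc4c3)ncc2cc1S(=O)(=O)c1ccc(F)cc1F`: 15000 nM

In a functional assay on K562 cells (Homo sapiens) for inhibition, read by trypan blue exclusion, with a stated time of 72 h (on this read-out higher numbers stand for weaker inhibition and lower numbers for stronger inhibition), compound 3 stands at the highest of the three numbers, with the steps to compound 1 and to compound 2 both beyond the scatter. Compound 4 `O=c1c(S(=O)(=O)c2ccc(F)cc2F)cc2cnc(Nc3ccc4[nH]ccc4c3)nc2n1CC1CCCC1` differs from compound 3 by cyclopentylmethyl in place of hydrogen on an aromatic nitrogen. The measured steps that bear on this are a 15-fold higher number from compound 1 to compound 3 (1.18 log units; beyond the scatter) and a 15-fold higher number from compound 2 to compound 3 (1.18 log units; beyond the scatter), both large and both running in the opposite direction to the change now made; the step of no change at the digits printed from compound 1 to compound 2 (within the scatter) shows that exchanging one such group for another left the number unchanged within the scatter. Compound 4 is therefore expected to show a large fall, a 15-fold lower number from compound 3 to compound 4 (1.18 log units; beyond the scatter). The estimate for compound 4 is 1000 nM, with a range from 400 nM to 3000 nM.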

Compound 4, half-maximal inhibitory concentration: 7000 nM
Compound 4: the middle estimate sits 7.0-fold (0.85 log units) below what was measured, and the stated range ends below it.
By their numbers in this assay, from the lowest: compounds 1 and 2 (each within the scatter of the next); then compound 4; then compound 3.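

In this assay a group on this aromatic nitrogen does not by itself bring the full gain, since cyclopentylmethyl gives only a modest fall (a 2.1-fold lower number from compound 3 to compound 4 (0.33 log units; beyond the scatter)). Exchanging one group for another here is also not always neutral, as cyclopentyl on the saturated chain carbon gives a weaker result than either cyclopropyl (a 7.0-fold higher number from compound 2 to compound 4 (0.85 log units; beyond the scatter)) or ethyl (a 7.0-fold higher number from compound 1 to compound 4 (0.85 log units; beyond the scatter)). Nothing measured here accounts for this difference.

The compounds shown leave open whether a butyl chain or a piperidin-4-ylmethyl group, which carries an amine, on this nitrogen would stay level with compound 1 or fall back towards compound 4.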